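The source may hold more compounds than are shown below. What is called first, only, known or untested is meant among the compounds shown, and "the series" means these compounds.

Measured so far in an ADME assay on HepG2 cells (Homo sapiens) for cytotoxicity, read by MTT assay, with a stated time of 72 h; on this read-out higher numbers stand for lower toxicity in this test and lower numbers for higher toxicity in this test:
- compound 1, `O=[N+]([O-])c1c(CS(=O)(=O)c2ccccc2)nc2c(C#Cc3cccnc3)cc(Cl)cn12`: > 3900 nM
- compound 2, `O=[N+]([O-])c1c(CS(=O)(=O)c2ccccc2)nc2c(C#CCO)cc(Cl)cn12`: 10100 nM

Compound 1 stands only as a limit in this assay, (the limit of > 3900 nM in this assay, at which 1 of the 2 values shown sits); no number is known for it. Compound 2 gives 10100 nM in this assay. Among the measured compounds shown here, the one measured step, a step that the limit leaves unreadable from compound 1 to compound 2, cannot be sized, since the limit on compound 1 leaves its extent unreadable.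

Compound 3, `O=[N+]([O-])c1c(CS(=O)(=O)c2ccccc2)nc2c(C#CC3(O)CCCC3)cc(Cl)cn12`, is not yet measured. It differs from compound 1 as follows: 1-hydroxycyclopentyl in place of pyridin-3-yl on a triple-bonded carbon. For the measured compounds named here, the only measured step that bears on it is the change from compound 1 to compound 2, which likewise replaces the pyridin-3-yl on the triple-bonded carbon with a hydroxyl-bearing group; that step is unreadable in size. What can be said is that compound 2, carrying an alcohol in the same place, sits well clear of the limit reported for compound 1, and compound 3 also carries an alcohol there. A value in the region of compound 2 is therefore expected for compound 3, 8000 nM, within 3000 nM to 20000 nM. The step this implies, a step that the limit leaves unreadable from compound 1 to compound 3, is an expectation only, and its size against the limit cannot be read.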

Compound 3, half-maximal cytotoxic concentration: > 31300 nM
Compound 3: only a limit was reported; the forecaster's own chance of this, stated with the estimate: 30%; middle value at least 3.9-fold (0.59 log units) away from the limit.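

In this assay, the change at this triple-bonded carbon can now be sized between two alcohols: 1-hydroxycyclopentyl in place of hydroxymethyl gives an at least 3.0-fold higher number from compound 2 to compound 3 (0.49 log units; beyond the scatter), so the group at this position moves the read-out even when a hydroxyl is present in both compounds. Compound 3 is reported only as a limit: the limit of > 31300 nM in this assay, at which 1 of the 3 values shown sits. The steps starting from compound 1 cannot be read, because compound 1 is also reported only as a limit: the limit of > 3900 nM in this assay, at which 1 of the 3 values shown sits.

Still open, going by these compounds, is whether the cyclopentyl ring or the hydroxyl on it accounts for the step from hydroxymethyl to 1-hydroxycyclopentyl, a question that a plain cyclopentyl group carrying no hydroxyl at the same triple-bonded carbon would address. Also open, on these data alone, is how a longer hydroxyalkyl chain or an amine such as 1-aminocyclopentyl would read at this carbon, and how either would compare with the pyridin-3-yl of compound 1 once that compound has a number rather than a limit.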